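The source may hold more compounds than are shown below. What is called first, only, known or untested is meant among the compounds shown, and "the series" means these compounds.

Values in a functional assay on A549 cells (Homo sapiens) for cytotoxicity; a lower number here means that less compound is needed, a higher number that more compound is needed for the effect:
- compound 1 `COC1=C(C)C(=O)/C(=C(O)/C=C/c2cccc(OC)c2)C(=O)C1(C)C`: 2.8 ug/mL
- compound 2 `COC1=C(C)C(=O)/C(=C(O)/C=C/c2ccc(F)cc2)C(=O)C1(C)C`: 3.3 ug/mL
- compound 3 `C=Cc1ccccc1/C=C/C(O)=C1/C(=O)C(C)=C(OC)C(C)(C)C1=O`: 2.2 ug/mL

The three compounds share one core and differ only in the group on a double-bonded chain carbon bound to a double-bonded chain carbon. Compound 3, at 2.2 ug/mL, cannot be separated from the other two in this assay. Its nearest comparison is a 1.3-fold lower number from compound 1 to compound 3 (0.10 log units; within the scatter), and its furthest is a 1.5-fold lower number from compound 2 to compound 3 (0.18 log units; within the scatter). The remaining pair differs by a 1.2-fold higher number from compound 1 to compound 2 (0.07 log units; within the scatter).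

The next compound is compound 4 `COC1=C(C)C(=O)/C(=C(O)/C=C/c2cccs2)C(=O)C1(C)C`, in which thiophen-2-yl takes the place of 2-vinylphenyl at that same position: thiophen-2-yl in place of 2-vinylphenyl on a double-bonded chain carbon bound to a double-bonded chain carbon. For the measured compounds named here, no measured compound yet carries this five-membered ring, so the comparison rests on the three exchanges already seen. All three stayed within the scatter, the largest being a 1.5-fold lower number from compound 2 to compound 3 (0.18 log units; within the scatter). On that basis, no step beyond the scatter is expected in this assay, and no direction can be firmly predicted. The expected change would be a 1.3-fold higher number from compound 3 to compound 4 (0.10 log units; within the scatter), which is small. For compound 4 the estimated value is 2.8 ug/mL, with an expected range from 1.4 ug/mL to 5.6 ug/mL.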

Compound 4, concentration for half-maximal effect: 4.5 ug/mL
Compound 4: the middle estimate sits 1.6-fold (0.21 log units) below what was measured; measured number inside the range.
By their numbers in this assay, from the lowest: compounds 3, 1, 2 and 4 (each within the scatter of the next, the first and the last beyond it).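

In this assay, this position now gives its first exchange beyond the scatter, thiophen-2-yl in place of 2-vinylphenyl on a double-bonded chain carbon bound to a double-bonded chain carbon (a 2.0-fold higher number from compound 3 to compound 4 (0.31 log units; beyond the scatter)). The step is modest, and thiophen-2-yl cannot be separated from the other two groups, 4-fluorophenyl (a 1.4-fold higher number from compound 2 to compound 4 (0.13 log units; within the scatter)) and 3-methoxyphenyl (a 1.6-fold higher number from compound 1 to compound 4 (0.21 log units; within the scatter)), so the only separation among the four compounds lies between compound 3 and compound 4. Nothing available here explains that separation.

All four compounds carry an aromatic ring at this place, which leaves open whether an amine, a carboxylic acid or a longer saturated chain there would give numbers of a similar size. Going by these compounds, it also remains open whether the step belongs to the sulfur atom or to the five-membered ring, a question that furan-2-yl at the same place could help to settle.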